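Thiophene dihydropyrimidine esters against adenosine receptor A3

A few compounds are considered here, and "the series" means these few. Any claim that something is new, unique, unknown or untested is made for them only; others in the source may bear on it.

Measured so far in an assay on membranes from HeLa cells for displacement of a labelled ligand from adenosine receptor A3 (Homo sapiens), read by scintillation counting, with a stated time of 180 min, tested at 1 uM; a higher number here means more inhibition at the concentration tested (going by the name of the read-out), a lower number less inhibition:
compound 1, `COC(=O)C1=C(C)NC(=S)NC1c1cccs1`, gives 1%;
compound 2, `CCCOC(=O)C1=C(C)NC(=S)NC1c1cccs1`, gives 10%;
compound 3, `COC(=O)C1=C(C)N(C)C(=O)NC1c1ccsc1`, gives 22%.

Compound 1 and compound 2 share one core and differ by ethyl in place of hydrogen on a saturated chain carbon bound to an oxygen next to a carbonyl group. The step is a number 9 percentage points higher from compound 1 to compound 2 (within the scatter), so the two values cannot be separated with confidence. Compound 3 carries a different core; the difference between the two cores is not broken down here. Its value stands beyond the scatter above both compound 1 and compound 2, so among the three it is the highest in this assay.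

Compound 4, `CCCOC(=O)C1=C(C)N(C)C(=O)NC1c1ccsc1`, has not yet been measured in this assay. It is related to compound 3 by ethyl in place of hydrogen on a saturated chain carbon bound to an oxygen next to a carbonyl group, which is the same change as that from compound 1 to compound 2, made in the same place. That earlier step was small and within the scatter, and nothing here shows the change behaving differently on the core of compound 3, so a step of similar size is the working assumption.

From compound 3 to compound 4 the expected step is a number 6 percentage points higher from compound 3 to compound 4 (within the scatter), resting on compound 1 to compound 2 giving a number 9 percentage points higher from compound 1 to compound 2 (within the scatter). Compound 4 is thus estimated at 28% in this assay, within a range from 12% to 45%.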

Compound 4, a percentage reported as inhibition, at one concentration (the size of the read-out at that concentration, not a potency): 11%
Beside the measured number, compound 4's estimate is 17 percentage points above it; the measured number lies below the stated range.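

Propoxycarbonyl in place of methoxycarbonyl gives a number 11 percentage points lower from compound 3 to compound 4 (beyond the scatter) in this assay and so does not repeat the small step seen on the other core. The change therefore cannot be carried between these two cores as a step of fixed size: the same change on two cores in this assay, a number 9 percentage points higher (within the scatter) from compound 1 to compound 2 and a number 11 percentage points lower (beyond the scatter) from compound 3 to compound 4, 20 percentage points apart, beyond the scatter of two such steps

This rests on one pair per core, and the earlier step lies within the scatter, so it shows a dependence on the core but no clean reversal of direction, and the difference between the two cores is not broken down far enough to say which part of it goes with the gap.

Left open is how the value runs with the ester chain on either core: an ethoxycarbonyl or a longer chain such as butoxycarbonyl would show whether the drop on the second core is steady or confined to propoxycarbonyl. Also open is whether a carboxylic acid or an amide in place of the ester would hold the value of the methyl ester, and single-concentration percentages of this kind say nothing of potency for any of these compounds.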